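The compounds below may be only part of what the source reports. "The series", "measured", "known", "first", "only" and "open" are said of these compounds alone.

Compound 2, `COc1ccc(CNc2cc(OC)c(OC)c(OC)c2)cc1F`, is the reference point. In a functional assay on KYSE-450 cells (Homo sapiens) for inhibition, read by MTT assay, with a stated time of 48 h (a higher number here means a weaker inhibitor, a lower number a stronger inhibitor), compound 2 gives 46200 nM, the lowest of the three numbers shown; compound 3, `COc1ccc(CNc2cc(OC)c(OC)c(OC)c2)cc1Cl`, gives 47800 nM and compound 1, `COc1ccc(CNc2cc(OC)c(OC)c(OC)c2)cc1C`, gives 73800 nM, and all three lie within the scatter of one another. Compound 4, `C/C=C/C(=O)N(Cc1ccc(OC)c(F)c1)c1cc(OC)c(OC)c(OC)c1`, is made from compound 2 by a single change: (prop-1-en-1-yl)carbonyl in place of hydrogen on a nitrogen on an aromatic ring. The measured steps, a 1.6-fold lower number from compound 1 to compound 2 (0.20 log units; within the scatter), a 1.5-fold lower number from compound 1 to compound 3 (0.19 log units; within the scatter) and a 1.0-fold higher number from compound 2 to compound 3 (0.01 log units; within the scatter), all swap one small group on an aromatic carbon, so none of them bears on an acyl group entering at the nitrogen, and the data give no measured guide here. Any step is therefore uncertain; a large change of this kind is expected to move the number well beyond the scatter, and the estimate for compound 4 is 5000 nM, in the range 500 nM to 50000 nM, meaning an expected step of a 9.2-fold lower number from compound 2 to compound 4 (0.97 log units; beyond the scatter).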

Compound 4, half-maximal inhibitory concentration: 1400 nM
Compound 4: the middle estimate sits 3.6-fold (0.55 log units) above what was measured; the measured number falls inside the stated range.
By their numbers in this assay, from the lowest: compound 4; then compounds 2, 3 and 1 (each within the scatter of the next).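

In this assay, (prop-1-en-1-yl)carbonyl in place of hydrogen on the nitrogen gives a 33-fold lower number from compound 2 to compound 4 (1.52 log units; beyond the scatter). The swaps of one small group on an aromatic carbon among compound 1, compound 2 and compound 3 all stayed within the scatter, so the nitrogen is the first place shown where a single change moves the number beyond it. Nothing available explains this gain in potency.

Going by these compounds, it remains open whether the whole acyl group is needed or the carbonyl alone would do. An acetyl group, a saturated butanoyl chain or a simple methyl on the same nitrogen would help separate these possibilities.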